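Trimming the benzylic amine in a diaryl ether series

The compounds below may be only part of what the source reports. "The series", "measured", "known", "first", "only" and "open" are said of these compounds alone.

Compound 1 `CCN1CCN(Cc2c(OC)cc(Oc3cccc(Nc4ccccc4)c3)cc2OC)CC1`: 5090 nM
Compound 2 `COc1ccc(CCCNCc2c(OC)cc(Oc3ccc(Nc4ccccc4)cc3)cc2OC)cc1`: 2180 nM
Compound 3 `COc1cc(Oc2cccc(Nc3ccccc3)c2)cc(OC)c1CNCc1ccc(Cl)cc1`: 4850 nM

In a functional assay on HCT-15 cells (Homo sapiens) for inhibition, read by MTT assay, with a stated time of 72 h (on this read-out higher numbers stand for weaker inhibition and lower numbers for stronger inhibition), compound 3 gives 4850 nM, the second highest of the three numbers; compound 1 gives 5090 nM and compound 2 gives 2180 nM. Compound 3 and compound 1 differ only at the saturated chain carbon bound to the aromatic carbon, and a 1.0-fold lower number from compound 1 to compound 3 (0.02 log units; within the scatter). Compound 2 sits beyond the scatter below both, but it differs from them in more than one place, so its values alone are reported.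

Compound 4 `CNCc1c(OC)cc(Oc2cccc(Nc3ccccc3)c2)cc1OC` is not yet measured. It differs from compound 3 by hydrogen in place of 4-chlorophenyl on a saturated chain carbon bound to an amine nitrogen, so (4-chlorobenzyl)amino becomes methylamino. Going by the values given here, no measured step covers this change: the only single-place step, from compound 1 to compound 3, exchanged one larger amine for another and stayed within the scatter. Removing the 4-chlorophenyl leaves a much smaller amine, and compound 4 is expected to give a somewhat higher number, a 1.9-fold higher number from compound 3 to compound 4 (0.27 log units; within the scatter), though with wide uncertainty. The estimate for compound 4 is 9000 nM, with a range from 3000 nM to 30000 nM.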

Compound 4, half-maximal inhibitory concentration: 8930 nM
Compound 4: the middle estimate sits 1.0-fold (0.00 log units) above what was measured, and the stated range covers the measured number.
By their numbers in this assay, from the lowest: compound 2; then compounds 3, 1 and 4 (each within the scatter of the next).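

In this assay, removing the 4-chlorophenyl from the saturated chain carbon bound to an amine nitrogen gives a step within the scatter (a 1.8-fold higher number from compound 3 to compound 4 (0.27 log units; within the scatter)), so the loss of this aromatic ring and its 7 heavy atoms cannot be told from repeat variation. The exchange of 4-ethylpiperazin-1-yl for methylamino reads the same way (a 1.8-fold higher number from compound 1 to compound 4 (0.24 log units; within the scatter)), and the piperazine, benzylamine and methylamine compounds now stand within the scatter of one another. Nothing available explains why these changes of amine leave the read-out so little altered.

The compounds shown leave open whether a primary amine, a dimethylamino group or an amide on this carbon would also stay within the scatter. Compound 2 at 2180 nM differs from the others in more than one place, so what sets its number apart remains unresolved.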